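A few compounds are considered here, and "the series" means these few. Any claim that something is new, unique, unknown or untested is made for them only; others in the source may bear on it.

The compounds measured so far:

Compound 1 `COc1ccc(-c2ccnc(Nc3ccc(Cl)cc3Cl)n2)cc1` gives 23000 nM in a functional assay on HeLa cells (Homo sapiens) for antiproliferative activity, read by MTT assay; on this read-out higher numbers stand for weaker inhibition and lower numbers for stronger inhibition.
Compound 2 `O=[N+]([O-])c1ccc(Nc2nccc(-c3ccc(F)cc3)n2)cc1` gives 3510 nM in this assay.
Compound 3 `Cc1cccc(Nc2nccc(-c3ccc(Cl)cc3Cl)n2)c1` gives 7660 nM in this assay.

Among these three, compound 2 stands at the lowest number in this assay. The nearest to it is compound 3, whose number is higher by a margin beyond the usual scatter; the furthest is compound 1, whose number is higher still, also beyond the scatter. Compound 2 is therefore the strongest inhibitor of the three on this read-out.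

Compound 4 `O=[N+]([O-])c1ccc(Nc2nccc(-c3ccc(Cl)c(Cl)c3)n2)cc1` is yet to be measured. It differs from compound 2 in one place: 3,4-dichlorophenyl in place of 4-fluorophenyl on an aromatic carbon. Within the data shown here, no pair of measured compounds differing in a single place is available, so the size of this step cannot be read from the data. The step is expected to be small, without a direction that clears the scatter. Compound 4 is expected to give 2500 nM in this assay, within a range from 800 nM to 8000 nM. The expected step is a 1.4-fold lower number from compound 2 to compound 4 (0.15 log units; within the scatter).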

Compound 4, half-maximal inhibitory concentration: 1840 nM
Estimate against measurement, compound 4: 1.4-fold (0.13 log units) above, and the stated range covers the measured number.
By their numbers in this assay, from the lowest: compounds 4 and 2 (each within the scatter of the next); then compound 3; then compound 1.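

In this assay, among these compounds, the one pair differing in a single place shows a 1.9-fold lower number from compound 2 to compound 4 (0.28 log units; within the scatter), so the exchange of 4-fluorophenyl for 3,4-dichlorophenyl on the aromatic carbon next to the ring nitrogen leaves the read-out within the usual scatter. At this position, with the rest of compound 2 held fixed, the larger dichlorinated ring and the fluorinated ring cannot be told apart on this read-out. Nothing available bears on why the two groups read alike.

On these data alone, whether the same position also accepts something other than a substituted phenyl ring, such as an amine or a carboxylic acid, remains open. Also open, as far as these compounds go, is whether this exchange would read the same on the rest of compound 1 or compound 3.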